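The source may hold more compounds than are shown below. What is called first, only, known or untested is meant among the compounds shown, and "the series" means these compounds.

Compound 1 `C=CCn1c2ccc([N+](=O)[O-])cc2c(=O)n1Cc1ccccc1`: 192000 nM. Compound 2 `O=c1c2cc([N+](=O)[O-])ccc2n(CCCBr)n1Cc1ccccc1`: 25200 nM. Compound 3 `NC(=O)CCCn1c2ccc([N+](=O)[O-])cc2c(=O)n1Cc1ccccc1` gives only a limit of the assay, > 256000 nM.

In an ADME assay on L929 cells (Mus musculus) for cytotoxicity, read by resazurin assay, with a stated time of 48 h (on this read-out higher numbers stand for lower toxicity in this test and lower numbers for higher toxicity in this test), compound 2 holds the lowest of the two numbers, and the nearest is compound 1: a 7.6-fold lower number from compound 1 to compound 2 (0.88 log units; beyond the scatter). Compound 4 `CC(=O)OCCn1c2ccc([N+](=O)[O-])cc2c(=O)n1Cc1ccccc1` differs from compound 2 in one place: acetoxy in place of bromomethyl on a saturated chain carbon, two bonds along the chain from an aromatic nitrogen. Among the measured compounds shown here, two measured steps touch this position. Bringing in the bromine lowered the number, a 7.6-fold lower number from compound 1 to compound 2 (0.88 log units; beyond the scatter), and taking it out again raised it, an at least 10-fold higher number from compound 2 to compound 3 (1.00 log units; beyond the scatter). Removing the bromine in compound 4 is therefore expected to raise the number in this assay by a modest step, a 6.0-fold higher number from compound 2 to compound 4 (0.77 log units; beyond the scatter). Compound 4 is expected to give about 150000 nM, within a range from 50000 nM to 300000 nM.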

Compound 4, concentration lethal to 50% of the cells: > 256000 nM
Compound 4: no number, only a limit; the forecaster's own chance of this, stated with the estimate: 25%; middle value at least 1.7-fold (0.23 log units) from the limit.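

The acetoxy chain gives an at least 10-fold higher number from compound 2 to compound 4 (1.00 log units; beyond the scatter) in this assay and so shows that a second chain without bromine, after the carbamoyl chain, also escapes the low number of the 3-bromopropyl chain. Set against the allyl chain it gives an at least 1.3-fold higher number from compound 1 to compound 4 (0.12 log units; that floor lies within the scatter) and so shows no order between those two. Compound 3 and compound 4 both give only a limit, and the step between them cannot be read: the limit of > 256000 nM in this assay, at which 2 of the 4 values shown sit.

As far as these compounds go, whether a chain ending in chlorine or in an amine would lower the number as the 3-bromopropyl chain does stays open.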